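The source may report more compounds than this note shows. Statements on the series, on what has been measured and on what is new or still open speak of the compounds shown alone.

Measured compounds and their values:

- compound 1, `CCN(Cc1c(C(F)(F)F)nc2n(-c3c(C)cc(C)cc3C)c(Cl)cn12)CC1CC1`: 9 nM
- compound 2, `Cc1cc(C)c(-n2c(Cl)cn3c(CN(CCC(F)(F)F)CC4CC4)c(C(F)(F)F)nc23)c(C)c1`: 16 nM
- compound 3, `Cc1cc(C)c(-n2c(Cl)cn3c(CN(C)Cc4ccccc4)c(C(F)(F)F)nc23)c(C)c1`: 160 nM

All three share one core and differ only in the amine carried on the saturated chain carbon bound to an aromatic carbon. In an assay on cells for displacement of a labelled ligand from corticotropin-releasing factor receptor 1 (Homo sapiens), with a stated time of 100 min (on this read-out higher numbers stand for weaker inhibition and lower numbers for stronger inhibition), compound 3 gives the highest number of the three, so it is the weakest binder shown: the step of an 18-fold higher number from compound 1 to compound 3 (1.25 log units; beyond the scatter) and the step of a 10-fold higher number from compound 2 to compound 3 (1.00 log units; beyond the scatter) both lie beyond the scatter, while the step of a 1.8-fold higher number from compound 1 to compound 2 (0.25 log units; within the scatter) does not.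

Compound 4, `Cc1cc(C)c(-n2c(Cl)cn3c(CN4CCCCC4)c(C(F)(F)F)nc23)c(C)c1`, has not yet been measured. It differs from compound 3 in one place: piperidin-1-yl in place of benzyl(methyl)amino on a saturated chain carbon bound to an aromatic carbon. The two measured steps that end at compound 3 bear on this: both replace a dialkyl amine with the benzyl(methyl)amino group and both weaken binding clearly. Compound 4 goes the other way, back to an amine without the aromatic ring, so a step toward lower numbers in this assay is expected, though compound 4 is a ring amine unlike any measured compound. The expected step is a 5.3-fold lower number from compound 3 to compound 4 (0.73 log units; beyond the scatter). Compound 4 is therefore estimated at 30 nM, with a plausible range from 8 nM to 120 nM.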

Compound 4, inhibition constant: 1200 nM
The estimate for compound 4 lay 40-fold (1.60 log units) below the measured number; the whole stated range lies below it.
By their numbers in this assay, from the lowest: compounds 1 and 2 (each within the scatter of the next); then compound 3; then compound 4.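

At this position, in this assay giving up the aromatic ring of the benzyl(methyl)amino group does not by itself bring binding back: a 7.5-fold higher number from compound 3 to compound 4 (0.88 log units; beyond the scatter) shows that piperidin-1-yl, with 6 heavy atoms, does worse than the benzyl(methyl)amino group with 9. Against the open-chain amines that carry a cyclopropylmethyl group the change is larger still, with a 75-fold higher number from compound 2 to compound 4 (1.88 log units; beyond the scatter) and a 130-fold higher number from compound 1 to compound 4 (2.12 log units; beyond the scatter) both printed as large, so compound 4 is the weakest binder of the four, and the order among the amines here is not set by the presence of an aromatic ring alone. Nothing available explains why this ring amine falls so far behind the others.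

The compounds shown cannot separate the effect of tying the amine into a ring from that of simply having fewer heavy atoms, since no open-chain amine of similar size, such as diethylamino, stands beside compound 4. Going by these compounds, whether other ring amines, such as pyrrolidin-1-yl or morpholin-4-yl, behave like piperidin-1-yl also remains open.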